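The compounds below may be only part of what the source reports. "The series", "measured", "known", "first", "only" and "open" are said of these compounds alone.

Measured so far:
Compound 1, `O=Cc1ccc(-c2cn3ccnc3c(-c3ccc4ncn(C5CCCCC5)c4c3)n2)cc1`: in a functional assay on MDA-MB-231 cells (Homo sapiens) for inhibition, read by sulforhodamine B assay, with a stated time of 48 h, tested at 10 uM (a higher number here means more inhibition at the concentration tested (going by the name of the read-out), a lower number less inhibition), compound 1 gives 51.2%.
Compound 2, `CCc1ccc(-c2cn3ccnc3c(-c3ccc4ncn(Cc5ccccc5)c4c3)n2)cc1`: in this assay compound 2 gives 43.2%.

Within the data shown here, compound 2 has the lower of the two numbers, but its only neighbour, compound 1, lies within the usual scatter of repeated measurements, so the two cannot be told apart on these data. The two compounds also differ in more than one place, so nothing can be read from their pair about any single change.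

The next compound, compound 3, is `Cc1cccc(-c2cn3ccnc3c(-c3ccc4ncn(Cc5ccccc5)c4c3)n2)c1`. It differs from compound 2 in one place:
3-methylphenyl in place of 4-ethylphenyl on an aromatic carbon
The group that leaves and the group that enters are each a single six-membered aromatic ring of carbon only, without hydrogen-bond donors or acceptors, and they differ by a single carbon. Among the measured compounds shown here, no step between measured compounds is available to guide the expectation. For compound 3 the step from compound 2 is therefore expected to stay within the scatter, with no clear direction, as a number 1.2 percentage points lower from compound 2 to compound 3 (within the scatter). Compound 3 is estimated at 42%, with a likely range from 22% to 62%.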

Compound 3, a percentage reported as inhibition, at one concentration (the size of the read-out at that concentration, not a potency): 28.4%
Estimate against measurement, compound 3: 13.6 percentage points above; the range from low to high includes it.
By their numbers in this assay, from the lowest: compound 3; then compounds 2 and 1 (each within the scatter of the next).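

In this assay, replacing 4-ethylphenyl with 3-methylphenyl gives a number 14.8 percentage points lower from compound 2 to compound 3 (beyond the scatter), the first difference in this set that can be read as a real one. It shows that this position, an aromatic carbon of the six-membered ring with 2 nitrogen, is not indifferent to the group it carries, even when the two groups are close relatives: each is a single aromatic ring of carbon only, with no hydrogen-bond donors or acceptors, and they differ by just one carbon. Nothing available here explains why the number falls.

The two names also show that the change alters two things at once, the length of the small alkyl group and its place on the phenyl ring, so this single step cannot say which of them goes with the lower number. The groups 4-methylphenyl and 3-ethylphenyl would pull those two apart, and a phenyl ring carrying an amine or a carboxylic acid would show whether the number in this position stays level or moves when the group is anything other than plain carbon substituents.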